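The source may report more compounds than this note shows. Statements on the series, on what has been measured and on what is new or still open speak of the compounds shown alone.

In a functional assay on PC-3 cells (Homo sapiens) for inhibition, read by sulforhodamine B assay, with a stated time of 48 h, tested at 10 uM (on this read-out lower numbers stand for less inhibition of growth and higher numbers for more inhibition of growth at the one concentration tested), compound 1 `COc1cc(-c2nc(N)n(CC(=O)Nc3ccc(/C(C)=N\O)cc3)n2)cc(OC)c1OC` gives 23.3%. Compound 2 `c1ccc(-c2nc3sc(-c4ccccc4)cn3n2)cc1` gives 37% and compound 3 `COc1ccc(-c2nc3sc(-c4ccc(Cl)cc4)cn3n2)cc1` gives 41.9%. Compound 3 holds the highest of the three numbers; its gap to compound 2 lies within the scatter, while its gap to compound 1 lies beyond the scatter, so only compound 1 stands apart on this read-out. Compound 4 `Clc1ccc(-c2cn3nc(-c4ccccc4)nc3s2)cc1` has not yet been measured. It differs from compound 3 in one place: hydrogen in place of methoxy on an aromatic carbon. Compound 2 shares the core of compound 3 and compound 4 but carries neither the methoxy group nor the chlorine; its number and that of compound 3 sit within the scatter of each other, which gives no sign that the methoxy group moves the read-out. Among the measured compounds shown here, no step between measured compounds isolates this single change. The expected step, a number 4.9 percentage points lower from compound 3 to compound 4 (within the scatter), is small and not beyond the scatter. Compound 4 is expected to give 37% in this assay, within 23% to 51%.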

Compound 4, percent growth inhibition at one concentration: 31%
For compound 4 the middle estimate is 6 percentage points above the measured one, and the stated range covers the measured number.
By their numbers in this assay, from the lowest: compounds 1, 4, 2 and 3 (each within the scatter of the next, the first and the last beyond it).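

In this assay, among the compounds shown here, the methoxy group, on an aromatic carbon para to a large group, now has a step of its own: hydrogen in its place gives a number 10.9 percentage points lower from compound 3 to compound 4 (beyond the scatter) and thus a modest loss of growth inhibition that no earlier pair could isolate. For the compounds shown here, the chlorine can also be read alone for the first time, and a number 6 percentage points lower from compound 2 to compound 4 (within the scatter) does not separate chloro from hydrogen on an aromatic carbon. No supporting data bear on these steps, which stand as observations without an explanation.

As far as these compounds go, whether the methoxy step also holds without the chlorine remains open, as the methoxy group is read here on a single chlorinated compound pair. From the compounds shown here alone, it is equally open how a hydroxyl group, an amine or a longer alkoxy chain would read at this place.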